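The compounds below may be only part of what the source reports. "The series", "measured", "known", "first", "only" and "open" are said of these compounds alone.

In a functional assay on HeLa cells (Homo sapiens) for cytotoxicity, read by MTT assay, with a stated time of 2 days (on this read-out higher numbers stand for weaker inhibition and lower numbers for stronger inhibition), compound 1 `Cc1ccc2c(=O)[nH]c(-c3cccc(OC(F)(F)F)c3)nc2c1` gives only a limit, > 50000 nM. Compound 2 `CCN(CC)c1ccc2nc(-c3cccc4ccccc34)[nH]c(=O)c2c1` gives 4 nM, and compound 3 `COc1cccc(-c2nc3cc(C)ccc3c(=O)[nH]2)c1` gives 8940 nM, the higher of the two numbers shown. Compound 4 `Cc1ccc2c(=O)[nH]c(-c3cccc(F)c3)nc2c1` has not yet been measured in this assay; set against compound 3 it carries fluoro in place of methoxy on an aromatic carbon. Going by the values given here, the one measured step touching the same aromatic carbon is an at least 5.5-fold lower number from compound 1 to compound 3 (0.74 log units; beyond the scatter), a change on the oxygen rather than its removal, and its size is only a bound since compound 1 sits at the limit of > 50000 nM in this assay, at which 1 of the 3 values shown sits. That step offers a modest guide at best. Compound 4 is therefore expected to show a step of a 1.3-fold higher number from compound 3 to compound 4 (0.13 log units; within the scatter) that stays within the scatter. Compound 4 is estimated at 12000 nM, within 3000 nM to 50000 nM.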

Compound 4, half-maximal inhibitory concentration: > 50000 nM
Compound 4 gave a limit, no number (the forecaster's own chance of this, stated with the estimate: 30%); middle value at least 4.1-fold (0.61 log units) from the limit.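

Fluoro in place of methoxy on this aromatic carbon gives an at least 5.5-fold higher number from compound 3 to compound 4 (0.74 log units; beyond the scatter) in this assay, so the oxygen-linked methyl cannot be swapped for fluoro without a step beyond the scatter. Of compounds 1, 3 and 4, only compound 3 gives a number, and compound 4, like compound 1, gives only a limit: the limit of > 50000 nM in this assay, at which 2 of the 4 values shown sit. The step between compound 1 and compound 4 cannot be read.

On these data alone, it remains open whether a hydroxyl, an amine or a longer alkoxy chain on this carbon would give a number, and how compound 1 and compound 4 compare.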